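The compounds below may be only part of what the source reports. "The series", "measured", "known", "first", "only" and "open" are said of these compounds alone.

Compound 1 `c1ccc2c(c1)ccn2-c1nc(N2CCCCC2)nc2ccccc12` and compound 2 `CN1CCN(c2nc(-n3ccc4ccccc43)c3ccccc3n2)CC1` share one core and differ only in the ring that hangs from it. In a functional assay on DU-145 cells (Homo sapiens) for antiproliferative activity, read by MTT assay (a higher number here means a weaker inhibitor, a lower number a stronger inhibitor), compound 1 gives 50 ug/mL, while compound 2 gives 20.8 ug/mL; the step between them, a 2.4-fold lower number from compound 1 to compound 2 (0.38 log units; beyond the scatter), is the only one measured, and it leaves compound 2 with the lowest of the two numbers. Compound 3 `Fc1ccc(N2CCN(c3nc(-n4ccc5ccccc54)c4ccccc4n3)CC2)cc1` keeps the ring of compound 2 and alters it further: 4-fluorophenyl in place of methyl on an amine nitrogen in a ring. Going by the values given here, no measured step swaps a methyl for an aryl group at this place, so the single step from compound 1 to compound 2 bears on it only loosely, showing that changes in this part of the molecule shift the number modestly. A small step of a 1.4-fold lower number from compound 2 to compound 3 (0.14 log units; within the scatter) toward a lower number is therefore expected. The estimate for compound 3 is 15 ug/mL, with a range from 5 ug/mL to 45 ug/mL.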

Compound 3, half-maximal inhibitory concentration: 50 ug/mL
Beside the measured number, compound 3's estimate is 3.3-fold (0.52 log units) below it; measured number above the stated range.
By their numbers in this assay, from the lowest: compound 2; then compounds 1 and 3 (each within the scatter of the next).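

In this assay, 4-fluorophenyl in place of methyl on the amine nitrogen in the ring gives a 2.4-fold higher number from compound 2 to compound 3 (0.38 log units; beyond the scatter). Going by these compounds alone, this is the first step that changes what sits on that nitrogen, as the earlier step, a 2.4-fold lower number from compound 1 to compound 2 (0.38 log units; beyond the scatter), exchanged the whole ring. Together, the two steps leave compound 2, with methyl on this nitrogen, with the lowest number of the compounds shown, and here a group of seven heavy atoms with an aromatic ring goes with a higher number than a single carbon. Nothing available explains this rise.

Going by these compounds, whether the rise goes with the aromatic ring or with its fluorine stays open, and a plain phenyl group on this nitrogen would separate the two. On these data alone, how a hydrogen, an ethyl group or a benzyl group would fare at this place also remains open.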